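Iodo on the benzoylphenyl sulfonamide series: compound 4

The compounds below may be only part of what the source reports. "The series", "measured", "known", "first", "only" and "open" are said of these compounds alone.

Working notes on the sulfonamide set. In an assay on CHO cells for binding affinity to integrin alpha-1 (Homo sapiens), read by WST assay, with a stated time of 2 h (on this read-out higher numbers stand for an effect only at larger amounts of compound and lower numbers for an effect already at smaller amounts), compound 1 `CC(=O)c1cccc(NS(=O)(=O)c2ccc(Cl)cc2Cl)c1` reads "not active" (no number reported) and compound 2 `O=C(c1ccccc1)c1cccc(NS(=O)(=O)c2ccccc2)c1` likewise reads "not active" (no number reported), so no number places compound 2 on the scale; a second entry in this assay also carries no number. Compound 3 `O=C(c1ccccc1)c1ccc(NS(=O)(=O)c2ccc(I)cc2)cc1`, which carries the 4-iodophenyl group, gives 22000 nM in this assay. Compound 4 `O=C(c1ccccc1)c1cccc(NS(=O)(=O)c2ccc(I)cc2)c1` differs from compound 2 by iodo in place of hydrogen on an aromatic carbon. Going by the values given here, no step between measured compounds is available for this change. The expectation is a gain in this assay, from no measurable effect to a weak one, roughly matching what compound 3 shows at 22000 nM. Compound 4 is estimated at 30000 nM, within 8000 nM to 100000 nM, with a real chance of a limit only.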

Compound 4, half-maximal effective concentration: 40000 nM
The estimate for compound 4 lay 1.3-fold (0.12 log units) below the measured number, within the range that was stated.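

Going by these compounds alone, compound 2 carries no number, so no step from it to compound 4 can be read. The compounds shown leave open how large the change from phenyl to 4-iodophenyl is on this scale. Nothing available explains the result.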